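Swapping a Hexyl Chain for a Dichlorobenzyl Group

The compounds below may be only part of what the source reports. "The series", "measured", "known", "first", "only" and "open" are said of these compounds alone.

Compound 1 `CSc1nnc(COc2cc(C)c3c(C)cc(=O)oc3c2)o1` and compound 2 `CCCCCCSc1nnc(COc2cc(C)c3c(C)cc(=O)oc3c2)o1` share one core and differ only by a pentyl group on the chain bound to sulfur. In a functional assay on MCF7 cells (Homo sapiens) for antiproliferative activity, read by MTT assay, with a stated time of 24 h (on this read-out lower numbers stand for stronger inhibition and higher numbers for weaker inhibition), compound 1 gives only a limit, > 100000 nM. In this assay compound 2 likewise gives only a limit, > 100000 nM. The step that the two limits leave unreadable from compound 1 to compound 2 therefore cannot be sized, since both values sit at the limit of > 100000 nM in this assay, at which 2 of the 2 values shown sit. Compound 3 `Cc1cc(OCc2nnc(SCc3ccc(Cl)cc3Cl)o2)cc2oc(=O)cc(C)c12` carries 2,4-dichlorophenyl in place of pentyl on a saturated chain carbon bound to a sulfur. Among the measured compounds shown here, no measured step shows how such a change acts, so compound 3 is expected to remain near the limit, with an estimated a number no higher from compound 2 to compound 3 (the limit leaves the size open) and a value of 100000 nM, between 30000 nM and 300000 nM.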

Compound 3, half-maximal inhibitory concentration: < 5000 nM
Compound 3 gave a limit, no number (the forecaster's own chance of this, stated with the estimate: 65%); at least 20-fold (1.30 log units) between middle value and limit.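

In this assay, 2,4-dichlorophenyl on a saturated chain carbon bound to a sulfur gives an at least 20-fold lower number from compound 2 to compound 3 (1.30 log units; beyond the scatter). In the same place, this group in place of hydrogen gives an at least 20-fold lower number from compound 1 to compound 3 (1.30 log units; beyond the scatter), so a change here can move the read-out, which the two earlier limits could not show. The value of compound 3, < 5000 nM, is itself a limit and not a number.

The compounds shown leave open whether the ring alone or its two chlorines account for these steps, and a plain benzyl group would help separate the two.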